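Methyl for bromo on the anilino ring of compound 3

The source may hold more compounds than are shown below. What is called first, only, known or untested is meant among the compounds shown, and "the series" means these compounds.

Compound 3 `CCOC(=O)C1=C(Nc2ccc(Br)cc2)S/C(=C\c2ccc[nH]2)C1=O` is the reference for this step. In a functional assay on MCF7 cells (Homo sapiens) for inhibition, read by MTT assay, with a stated time of 72 h, tested at 10 uM (on this read-out lower numbers stand for less inhibition and higher numbers for more inhibition at the one concentration tested (going by the name of the read-out)), compound 3 gives < 10%, which is a limit of the assay rather than a number. Compound 1 `CCOC(=O)C1=C(Nc2ccccc2)S/C(=C\c2ccc(C(=O)O)cc2)C1=O` gives < 10%, likewise a limit. Compound 2 `CCOC(=O)C1=C(Nc2ccccc2)S/C(=C\c2cccc(C(=O)O)c2)C1=O` gives < 10%, also a limit. The step that the two limits leave unreadable from compound 1 to compound 2 is therefore unreadable. Compound 4 `CCOC(=O)C1=C(Nc2ccc(C)cc2)S/C(=C\c2ccc[nH]2)C1=O` differs from compound 3 by methyl in place of bromo on an aromatic carbon. Among the compounds with values here, no measured step touches this change; the only bearing comes from the limit of < 10% in this assay, at which 3 of the 3 values shown sit, so no step beyond the scatter is expected, and the step that the limit leaves unreadable from compound 3 to compound 4 is the estimate. Compound 4 is expected to give 5%, within 0% to 20%, most probably reported again as a limit.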

Compound 4, a percentage reported as inhibition, at one concentration (the size of the read-out at that concentration, not a potency): < 10%
Compound 4 gave a limit, no number (the forecaster's own chance of this, stated with the estimate: 75%); the middle value does not contradict the limit.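

Compound 3 and compound 4 are both reported only as limits, so no step can be read for methyl in place of bromo on an aromatic carbon. The compounds shown leave open which change to the shared core, if any, would give a readable inhibition.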